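A few compounds are considered here, and "the series" means these few. Any claim that something is new, unique, unknown or untested is made for them only; others in the source may bear on it.

Values in a functional assay on MDA-MB-231 cells (Homo sapiens) for cytotoxicity, read by MTT assay, with a stated time of 24 h; a lower number here means a stronger inhibitor, a higher number a weaker inhibitor:

- Compound 1 `Cc1ccc(/C=C2\CN(Cc3cn(Cc4ccc(F)cc4)nn3)C/C(=C\c3ccc(C)cc3)C2=O)cc1` gives 26800 nM
- Compound 2 `COc1ccc(/C=C2\CN(C(=S)SCc3cn(Cc4cccc(Cl)c4)nn3)C/C(=C\c3ccc(OC)cc3)C2=O)cc1` gives 32000 nM
- Compound 3 `Cc1ccc(/C=C2\CN(Cc3cn(Cc4cccc(Cl)c4)nn3)C/C(=C\c3ccc(C)cc3)C2=O)cc1` gives 9000 nM

Compound 3 has the lowest number of the three, so it is the strongest inhibitor so far in this assay. The next compound, compound 4 `Cc1ccc(/C=C2\CN(Cc3cn(Cc4ccccc4F)nn3)C/C(=C\c3ccc(C)cc3)C2=O)cc1`, keeps the rest of compound 3 and changes one group: 2-fluorophenyl in place of 3-chlorophenyl, on a saturated chain carbon bound to an aromatic nitrogen (2-fluorophenyl in place of 3-chlorophenyl on a saturated chain carbon bound to an aromatic nitrogen). Put another way, 3-chlorobenzyl becomes 2-fluorobenzyl.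

Among the measured compounds shown here, only one measured step bears on this change. It is a 3.0-fold lower number from compound 1 to compound 3 (0.47 log units; beyond the scatter), a modest gain on going from a 4-fluorophenyl group to the 3-chlorophenyl group. Compound 2 differs from compound 3 in more than one place, so it gives no clean comparison. For the measured compounds named here, no measured compound carries the 2-fluorophenyl group, which makes any forecast uncertain. Still, compound 4 loses the 3-chlorophenyl group and, like compound 1, carries a fluorophenyl group, so part of that gain is expected to be lost. The expected change is a 2.2-fold higher number from compound 3 to compound 4 (0.35 log units; beyond the scatter), towards a weaker inhibitor. For compound 4 the estimated value is 20000 nM, with an expected range from 9000 nM to 42000 nM.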

Compound 4, half-maximal inhibitory concentration: 10000 nM
Compound 4: the middle estimate sits 2.0-fold (0.30 log units) above what was measured, within the range that was stated.
By their numbers in this assay, from the lowest: compounds 3 and 4 (each within the scatter of the next); then compounds 1 and 2 (each within the scatter of the next).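

In this assay, replacing 3-chlorobenzyl with 2-fluorobenzyl gives a 1.1-fold higher number from compound 3 to compound 4 (0.05 log units; within the scatter), so the two groups cannot be told apart by this measurement, and a chlorine on the phenyl ring is not needed to reach the level of compound 3. The other new comparison gives a 2.7-fold lower number from compound 1 to compound 4 (0.43 log units; beyond the scatter): the 4-fluorophenyl and 2-fluorophenyl groups carry the same atoms and differ only in where the fluorine sits on the ring, so among these compounds, having a fluorine on the ring does not settle the result, and where it sits makes a modest difference. Nothing available explains this difference between the two fluorinated groups.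

The step from compound 3 to compound 4 changes both the halogen and its place on the ring, so the compounds shown do not separate these two changes; the 2-chlorophenyl and 3-fluorophenyl groups would be the direct tests. They also leave open whether a halogen is needed at all, which a plain phenyl group at the same place would address.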